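This account rests on a few compounds, and the source may have more. Where it says the series, first, only, none or still open, it means among the compounds named here.

Measured so far in a physicochemical assay for permeability, using PAMPA; a lower number here means that the compound crosses the layer more slowly, a higher number that the compound crosses the layer faster:
- compound 1 `Cc1cccc(F)c1-c1nc(CN2CCC(C(=O)NCCCN3C[C@H](C)C[C@H](C)C3)CC2)c(C)o1`: 234 10^-6 cm/s
- compound 2 `CCc1ccccc1-c1nc(CN2CCC(C(=O)NCCCN3C[C@H](C)C[C@H](C)C3)CC2)c(C)o1`: 106 10^-6 cm/s

Of these two numbers, the lower belongs to compound 2, at 106 10^-6 cm/s. The next compound, compound 3 `Cc1cccc(C)c1-c1nc(CN2CCC(C(=O)NCCCN3C[C@H](C)C[C@H](C)C3)CC2)c(C)o1`, differs from it by 2,6-dimethylphenyl in place of 2-ethylphenyl on an aromatic carbon, with 2,6-dimethylphenyl in place of 2-ethylphenyl. Within the data shown here, only one measured step bears on this change: a 2.2-fold lower number from compound 1 to compound 2 (0.34 log units; beyond the scatter), in which 2-ethylphenyl also entered on an aromatic carbon. Among the measured compounds shown here, no measured compound carries 2,6-dimethylphenyl, so the basis is thin. A step of similar modest size towards a higher number is expected in this assay. The estimated change is a 1.8-fold higher number from compound 2 to compound 3 (0.25 log units; within the scatter). The estimate for compound 3 is 190 10^-6 cm/s, with an expected range of 95 10^-6 cm/s to 380 10^-6 cm/s.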

Compound 3, apparent permeability: 254 10^-6 cm/s
Compound 3: the middle estimate sits 1.3-fold (0.13 log units) below what was measured; low and high end bracket the measured number.
By their numbers in this assay, from the lowest: compound 2; then compounds 1 and 3 (each within the scatter of the next).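

In this assay, rearranging the same carbons from 2-ethylphenyl to 2,6-dimethylphenyl on this aromatic carbon gives a step beyond the scatter (a 2.4-fold higher number from compound 2 to compound 3 (0.38 log units; beyond the scatter)), so the lower number of compound 2 cannot be read as a matter of atom content alone. Methyl in place of fluoro leaves the number within the scatter (a 1.1-fold higher number from compound 1 to compound 3 (0.04 log units; within the scatter)), so the two 2,6-disubstituted phenyl groups are not separated here. No measurement bears on the cause of either step. Still open, from the compounds shown here alone, is how 2-methoxyphenyl, 2-chlorophenyl or unsubstituted phenyl would read at this place.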